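Swapping 3-methylpiperidin-1-yl for (5-methylpyridin-2-yl)amino

The source may report more compounds than this note shows. Statements on the series, on what has been measured and on what is new or still open speak of the compounds shown alone.

In a functional assay on HCT-116 cells (Homo sapiens) for antiproliferative activity, read by MTT assay, with a stated time of 48 h (a higher number here means a weaker inhibitor, a lower number a stronger inhibitor), compound 1 `Cc1c(C(=O)OCCCN(C)C)oc2ccc(N(Cc3ccc(Br)cc3)S(=O)(=O)c3ccc(Br)cc3)cc12` gives 7050 nM and compound 2 `Cc1c(C(=O)NCC(O)CO)oc2ccc(N(Cc3ccc(Br)cc3)S(=O)(=O)c3ccc(Br)cc3)cc12` gives 11500 nM, two values within the scatter of each other. Compound 3 `Cc1c(C(=O)N2CCCC(C)C2)oc2ccc(N(Cc3ccc(Br)cc3)S(=O)(=O)c3ccc(Br)cc3)cc12` gives 28300 nM as the highest number of the three, which makes it the weakest inhibitor here. Compound 4 `Cc1ccc(NC(=O)c2oc3ccc(N(Cc4ccc(Br)cc4)S(=O)(=O)c4ccc(Br)cc4)cc3c2C)nc1` has (5-methylpyridin-2-yl)amino in place of 3-methylpiperidin-1-yl on a carbonyl carbon. Two measured steps involve the same group: a 4.0-fold higher number from compound 1 to compound 3 (0.60 log units; beyond the scatter) and a 2.5-fold higher number from compound 2 to compound 3 (0.39 log units; beyond the scatter) are both modest. Among the compounds with values here, no measured compound has an aromatic ring at this place, so the direction is uncertain. With compound 3 at 28300 nM as the highest number, a modest move to a lower number is expected: a 2.2-fold lower number from compound 3 to compound 4 (0.34 log units; beyond the scatter) is the estimated step. The estimate for compound 4 is 13000 nM (expected range 4500 nM to 35000 nM).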

Compound 4, half-maximal inhibitory concentration: > 40000 nM
Compound 4 was reported as a limit; the forecaster's own chance of this, stated with the estimate: 10%; middle value at least 3.0-fold (0.48 log units) away from the limit.
By their numbers in this assay, from the lowest: compounds 1 and 2 (each within the scatter of the next); then compound 3. At a limit, above all of these: compound 4.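

Compound 4 is reported only as a limit of the assay: the limit of > 40000 nM in this assay, at which 1 of the 4 values shown sits. The move to the aromatic ring is an at least 1.4-fold higher number from compound 3 to compound 4 (0.15 log units; that floor lies within the scatter), so the floor of this step does not separate the pair, while the other two steps, an at least 3.4-fold higher number from compound 2 to compound 4 (0.54 log units; beyond the scatter) and an at least 5.6-fold higher number from compound 1 to compound 4 (0.75 log units; beyond the scatter), are beyond the scatter. The first aromatic ring at this place, in (5-methylpyridin-2-yl)amino, therefore brings no measurable move to a lower number. The compounds shown leave open whether a phenylamino group or a carboxylic acid on this carbonyl carbon would give a lower number.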